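This account rests on a few compounds, and the source may have more. Where it says the series, first, only, none or still open, it means among the compounds named here.

Values so far in a functional assay on Jurkat cells (Homo sapiens) for cytotoxicity, read by MTT assay, with a stated time of 72 h; on this read-out lower numbers stand for stronger inhibition and higher numbers for weaker inhibition
- Compound 1 `O=C(Nc1ccc(C(=O)NO)cc1)Nc1ccc([N+](=O)[O-])cc1` gives 12700 nM
- Compound 2 `O=C(CCc1ccc(NC(=O)Nc2ccc(Cl)cc2)cc1)NO` gives 410 nM

Of these two, compound 2 has the lower number, and the gap between them lies beyond the usual scatter. The next compound, compound 3 `O=C(CCc1ccc(NC(=O)Nc2ccc([N+](=O)[O-])cc2)cc1)NO`, has nitro in place of chloro on an aromatic carbon, para to a large group. Among the compounds with values here, no measured pair isolates this exchange. Compound 1 carries the same nitro group but differs from compound 3 elsewhere, so its number cannot be read as the size of the exchange. Compound 3 keeps everything outside the changed group from compound 2, so its number is expected to stay far closer to that of compound 2 than to that of compound 1. A moderate step toward a higher number is expected in this assay, possibly not far beyond the scatter. The estimated step of a 2.0-fold higher number from compound 2 to compound 3 (0.29 log units; within the scatter) is the working expectation. For compound 3 the estimated value is 800 nM, with an expected range from 250 nM to 2500 nM in this read-out.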

Compound 3, half-maximal inhibitory concentration: 810 nM
Beside the measured number, compound 3's estimate is 1.0-fold (0.01 log units) below it; the measured number falls inside the stated range.
By their numbers in this assay, from the lowest: compounds 2 and 3 (each within the scatter of the next); then compound 1.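

In this assay the exchange of chloro for nitro on an aromatic carbon, para to a large group, can now be read on its own: a 2.0-fold higher number from compound 2 to compound 3 (0.30 log units; within the scatter) stays within the scatter, so this read-out does not separate the two groups at this position, even though nitro brings 3 heavy atoms and 2 hydrogen-bond acceptors where chloro has 1 heavy atom and 0 acceptors. With nitro held fixed, the exchange of hydroxycarbamoyl for 2-(hydroxycarbamoyl)ethyl on an aromatic carbon gives a 16-fold lower number from compound 1 to compound 3 (1.20 log units; beyond the scatter) and lies beyond the scatter, so among these compounds the large step belongs to that group and not to the nitro-for-chloro exchange. Nothing at hand explains either step.

Still open, on these data alone, is whether an amine or a methoxy group at the para position would also stay within the scatter of compound 2 and compound 3, since two groups say little about the range this position tolerates. Also open, as far as these compounds go, is how the number moves with a longer chain carrying the hydroxycarbamoyl group, such as 3-(hydroxycarbamoyl)propyl, and whether the step seen with nitro holds with chloro in its place.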